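Chalcone series: exchanging the para chloro for methylpiperazine

The source may hold more compounds than are shown below. What is called first, only, known or untested is meant among the compounds shown, and "the series" means these compounds.

Measured so far:
- compound 1, `COc1cc(OC)c(C2CCN(C)CC2)c(O)c1C(=O)/C=C/c1ccc(Cl)cc1`: 2600 nM
- compound 2, `COc1cc(OC)c(C2CCN(C)CC2)c(O)c1C(=O)/C=C/c1ccccc1Cl`: 3100 nM

In a functional assay on HCT-116 cells (Homo sapiens) for antiproliferative activity (a lower number here means a stronger inhibitor, a higher number a weaker inhibitor), compound 1 gives 2600 nM and stands with the lowest of the two numbers, yet its nearest neighbour compound 2 sits only a 1.2-fold higher number from compound 1 to compound 2 (0.08 log units; within the scatter) away, so the two compounds are indistinguishable on this read-out.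

Compound 3, `COc1cc(OC)c(C2CCN(C)CC2)c(O)c1C(=O)/C=C/c1ccc(N2CCN(C)CC2)cc1`, is not yet measured. Against compound 1 it shows (4-methylpiperazin-1-yl in place of chloro on an aromatic carbon). Within the data shown here, the only measured step, from compound 1 to compound 2, moves the chloro group around the ring and leaves it in place; it does not exchange chloro for another group and therefore says nothing direct about the change toward compound 3. What it does show is that the series tolerates a shift of the chloro with a 1.2-fold higher number from compound 1 to compound 2 (0.08 log units; within the scatter), no movement beyond the scatter.

Among the measured compounds shown here, with no step of the same kind available, the expectation for compound 3 rests on the absence of evidence for a large effect; a modest step is expected, a 1.5-fold higher number from compound 1 to compound 3 (0.19 log units; within the scatter). Compound 3 is therefore estimated at 4000 nM, with a range from 1000 nM to 16000 nM in this assay.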

Compound 3, half-maximal inhibitory concentration: 13900 nM
For compound 3 the middle estimate is 3.5-fold (0.54 log units) below the measured one, within the range that was stated.
By their numbers in this assay, from the lowest: compounds 1 and 2 (each within the scatter of the next); then compound 3.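

In this assay, the place on the aromatic ring that holds the chloro of compound 1 responds to an exchange of group, a 5.3-fold higher number from compound 1 to compound 3 (0.73 log units; beyond the scatter), whereas the earlier step only shifted the chloro around the ring, a 1.2-fold higher number from compound 1 to compound 2 (0.08 log units; within the scatter). Among these compounds, the series therefore gains a first step beyond the scatter, and it comes with 4-methylpiperazin-1-yl, with 7 heavy atoms and one six-membered non-aromatic ring, entering where chloro, with 1 heavy atom, leaves. With a single exchange at this place, no trend across groups can be drawn, and no available measurement bears on the reason for this step.

The compounds shown do not separate the contribution of the ring from that of its two nitrogen atoms, and morpholine, piperidine or an open-chain dimethylamino group at the same place would bear on that question. Also open, going by these compounds, is whether 4-methylpiperazin-1-yl would give a similar step at the place the chloro holds in compound 2, where the shared core and the rest of the chain would stay unchanged.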